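Sulfonyl sulfur substituents: the step to compound 3

The source may hold more compounds than are shown below. What is called first, only, known or untested is meant among the compounds shown, and "the series" means these compounds.

In a toxicity assay on Vero cells (Chlorocebus sabaeus) for cytotoxicity, read by MTT assay (a higher number here means a weaker inhibitor, a lower number a stronger inhibitor), compound 1 `CCOC(=O)NC(=O)c1ccsc1NC(=O)c1ccc(S(=O)(=O)N2CCCC2)cc1` gives 58.2 ug/mL and compound 2 `CCOC(=O)NC(=O)c1ccsc1NC(=O)c1ccc(S(=O)(=O)N2CCC(OC)CC2)cc1` gives 21 ug/mL as the lower of the two numbers. Compound 3 `CCOC(=O)NC(=O)c1ccsc1NC(=O)c1ccc(S(=O)(=O)Nc2ccc(F)cc2)cc1` has (4-fluorophenyl)amino in place of 4-methoxypiperidin-1-yl on a sulfonyl sulfur, a difference counted as (4-fluorophenyl)amino in place of 4-methoxypiperidin-1-yl on a sulfonyl sulfur and not yet tested. Among the compounds with values here, the only measured step at this place is a 2.8-fold lower number from compound 1 to compound 2 (0.44 log units; beyond the scatter) and it brings in no aromatic ring, so it bears only loosely. The expected change in this assay is a 1.3-fold higher number from compound 2 to compound 3 (0.11 log units; within the scatter) and no step beyond the scatter is expected. Compound 3 is expected at 27 ug/mL with an estimated range of 9 ug/mL to 80 ug/mL for now.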

Compound 3, half-maximal inhibitory concentration: 20.5 ug/mL
Compound 3: middle estimate off by 1.3-fold (0.12 log units), on the high side; the measured number falls inside the stated range.
By their numbers in this assay, from the lowest: compounds 3 and 2 (each within the scatter of the next); then compound 1.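

In this assay, (4-fluorophenyl)amino, with an aromatic ring and a hydrogen-bond donor, replaces the non-aromatic 4-methoxypiperidin-1-yl on the sulfonyl sulfur with a 1.0-fold lower number from compound 2 to compound 3 (0.01 log units; within the scatter), so this exchange of ring type and donor count does not separate the two compounds. Replacing pyrrolidin-1-yl with the same group gives a 2.8-fold lower number from compound 1 to compound 3 (0.45 log units; beyond the scatter), leaving compound 1 apart from both others. No evidence bearing on the cause of these numbers is at hand. Still open, going by these compounds, is whether morpholin-4-yl or open-chain dimethylamino on the sulfonyl sulfur reads with pyrrolidin-1-yl or with the other two groups, and whether the fluorine on the aromatic ring matters.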